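The compounds below may be only part of what the source reports. "The series", "measured", "known", "first", "only" and "open" are said of these compounds alone.

Measured so far:
compound 1 `CCOC(=O)c1cn(Cc2nnc(-c3cc(S(N)(=O)=O)c(SCc4ccccc4)cc3Cl)o2)nn1`, 108000 nM
compound 2 `NS(=O)(=O)c1cc(-c2nnc(CNS(=O)(=O)c3ccc(Cl)cc3)o2)c(Cl)cc1SCc1ccccc1`, 32000 nM

In a functional assay on HCT-116 cells (Homo sapiens) for cytotoxicity, read by MTT assay, with a stated time of 72 h (a higher number here means a weaker inhibitor, a lower number a stronger inhibitor), compound 2 gives 32000 nM, the lowest number of the two; compound 1 gives 108000 nM. Among the compounds with values here, the single measured step, a 3.4-fold lower number from compound 1 to compound 2 (0.53 log units; beyond the scatter), varied the same part of the shared core that is changed next. Compound 3 `NS(=O)(=O)c1cc(-c2nnc(/C=C/c3cccc(Cl)c3)o2)c(Cl)cc1SCc1ccccc1` carries this change: 2-(3-chlorophenyl)ethenyl in place of (((4-chlorophenyl)sulfonyl)amino)methyl on an aromatic carbon. One step of that size gives only a rough guide, so for compound 3 a step of similar size in either direction is expected, a 1.1-fold lower number from compound 2 to compound 3 (0.03 log units; within the scatter). Compound 3 is therefore estimated at 30000 nM, ranging from 8000 nM to 120000 nM.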

Compound 3, half-maximal inhibitory concentration: 12000 nM
Compound 3: middle estimate off by 2.5-fold (0.40 log units), on the high side, and the stated range covers the measured number.
By their numbers in this assay, from the lowest: compound 3; then compound 2; then compound 1.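

Among the three groups seen at this position on the shared core, 2-(3-chlorophenyl)ethenyl gives the lowest number in this assay (a 2.7-fold lower number from compound 2 to compound 3 (0.43 log units; beyond the scatter); a 9.0-fold lower number from compound 1 to compound 3 (0.95 log units; beyond the scatter)). It has no hydrogen-bond donors or acceptors, so within these compounds a lower number does not require them in this group. Nothing shown explains the drop.

As far as these compounds go, the ethenyl link and the 3-chlorophenyl ring enter together, so their separate contributions remain open. From the compounds shown here alone, how a simple amine or a carboxylic acid would read at this position also remains open.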